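Extending an Ethyl Chain on a Weak Inhibitor

The source may report more compounds than this note shows. Statements on the series, on what has been measured and on what is new or still open speak of the compounds shown alone.

Compound 1 `CCCc1nc(C)c2cnn(C/C=C/C(=O)OCC)c(=O)n12`: in a functional assay for inhibition, with Homo sapiens as the target (on this read-out higher numbers stand for weaker inhibition and lower numbers for stronger inhibition), compound 1 gives > 48000 nM, which is a limit of the assay rather than a number.
Compound 2 `CCCc1nc(C)c2cnn(CC(O)CO)c(=O)n12`: compound 2 gives > 48000 nM, again a limit.
Compound 3 `CCc1nc(C)c2cnn(CC)c(=O)n12`: compound 3 gives 75600 nM.

Compound 3 therefore stands as the only one of the three with a real number; the other two sit at the limit of > 48000 nM in this assay, at which 2 of the 3 values shown sit.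

Compound 4 `CCCc1nc(C)c2cnn(CC)c(=O)n12` differs from compound 3 by methyl in place of hydrogen on a saturated chain carbon, two bonds along the chain from an aromatic carbon. For the measured compounds named here, only one step between measured compounds is known, a step that the two limits leave unreadable from compound 1 to compound 2, and it changes a different part of the shared core; being unreadable from its two limits, it says nothing about a chain extension. Compounds 1 and 2 both carry the propyl chain that compound 4 gains, but each is a limit and gives no measure of that chain's effect. Going by the values given here, with no step bearing on this change, the expected step of a 1.0-fold lower number from compound 3 to compound 4 (0.00 log units; within the scatter) is none beyond the scatter. Compound 4 is estimated at 75000 nM, within a range from 30000 nM to 190000 nM.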

Compound 4, half-maximal inhibitory concentration: > 48000 nM
Compound 4 ended at the assay's limit; the forecaster's own chance of this, stated with the estimate: 45%; the middle value does not contradict the limit.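

No size can be read for the steps from compound 1, compound 2 or compound 3 to compound 4, because each step meets a limit of the assay: the limit of > 48000 nM in this assay, at which 3 of the 4 values shown sit.

The compounds shown leave open whether going from ethyl to propyl on this chain changes the result in this assay at all.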